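Indole to Fluorophenyl on the Benzylic Nitrogen Substituent

The source may hold more compounds than are shown below. What is called first, only, known or untested is meant among the compounds shown, and "the series" means these compounds.

Compound 1 `CNC(=O)c1cc(C(=O)NC2CCC2)cn(Cc2cccnc2)c1=O` gives 1.8 in a physicochemical assay for lipophilicity, at pH 7.4; a higher number here means a more lipophilic compound, a lower number a more polar compound.
Compound 2 `CNC(=O)c1cc(C(=O)NC2CC2)cn(Cc2cccc3[nH]ccc23)c1=O` gives 2.9 in this assay.
Compound 3 `CNC(=O)c1cc(C(=O)NC(C)C)cn(Cc2ccccc2)c1=O` gives 3.6 in this assay.

Among these three, compound 2 stands second highest in this assay. Its nearest neighbour is compound 3, which lies higher by a margin beyond the scatter; its furthest is compound 1, which lies lower by a larger margin, also beyond the scatter. Among the measured compounds shown here, the three differ from one another in more than one place, so no single step between them is isolated.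

Compound 4 `CNC(=O)c1cc(C(=O)NC2CC2)cn(Cc2ccccc2F)c1=O` is not yet measured. It differs from compound 2 in one place: 2-fluorophenyl in place of 1H-indol-4-yl on a saturated chain carbon bound to an aromatic nitrogen. The group that leaves carries a hydrogen-bond donor and two rings; the group that enters carries none and one ring, with a fluorine in place of the second ring.

Compound 3, with a plain benzyl group and no donor on that substituent, gives 3.6, a value above that of compound 2. On that basis a modest upward step is expected for compound 4 in this assay, estimated as a number 0.40 log units higher from compound 2 to compound 4 (beyond the scatter), likely beyond the scatter but not large. Compound 4 is therefore expected to give about 3.3, within a range from 2.8 to 3.8.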

Compound 4, distribution coefficient: 3
Estimate against measurement, compound 4: 0.30 log units above, within the range that was stated.
By their numbers in this assay, from the lowest: compound 1; then compounds 2 and 4 (each within the scatter of the next); then compound 3.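

At this place, on a saturated chain carbon bound to an aromatic nitrogen, putting 2-fluorophenyl in place of 1H-indol-4-yl gives in this assay a number 0.10 log units higher from compound 2 to compound 4 (within the scatter) and so leaves the two compounds indistinguishable by this read-out. Among the compounds shown here, this is the first single change isolated, and it shows that a swap from a group with two rings and a hydrogen-bond donor to a group with one ring, a fluorine and no donor need not produce a step beyond the scatter at this position. Nothing among the data shown accounts for how close these two numbers lie.

Compound 1 and compound 3 each differ from compound 4 in more than one place, so their steps to it cannot be read and they say nothing certain about this position on its own. Going by these compounds, it remains open how plain phenyl, 2-chlorophenyl or a phenyl ring carrying a carboxylic acid or an amine would read at this place with the rest of compound 4 held fixed, and so whether the fluorine has any part in the result.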